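Thioether variation on the cinnamamide series: toward compound 4

The compounds below may be only part of what the source reports. "The series", "measured", "known", "first", "only" and "open" are said of these compounds alone.

Measured compounds:
compound 1 `COc1ccc(SCc2ccc(/C=C/C(=O)Nc3ccccc3N)cc2)cc1OC`: 10.1%
compound 2 `Nc1ccccc1NC(=O)/C=C/c1ccc(CSc2ccc(F)cc2)cc1`: 7.09%
compound 3 `Nc1ccccc1NC(=O)/C=C/c1ccc(CSc2ccc(C(F)(F)F)cn2)cc1`: 6.07%

In a functional assay on HeLa cells (Homo sapiens) for inhibition, read by CCK-8 assay, with a stated time of 72 h, tested at 2 uM (a higher number here means more inhibition of growth at the concentration tested, a lower number less inhibition of growth), compound 3 stands lowest of the three numbers, but the gaps are small: a number 4 percentage points lower from compound 1 to compound 3 (within the scatter) and a number 1 percentage points lower from compound 2 to compound 3 (within the scatter), and likewise a number 3 percentage points lower from compound 1 to compound 2 (within the scatter). All three compounds thus sit within the scatter of one another.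

Compound 4 `Nc1ccccc1NC(=O)/C=C/c1ccc(CSCCc2ccccc2)cc1` differs from compound 3 as follows: phenethyl in place of 5-(trifluoromethyl)pyridin-2-yl on a sulfur. Going by the values given here, every measured step so far exchanges the group on that same sulfur, and none moved the read-out beyond the scatter. On that basis no step beyond the scatter is expected for compound 4 either, estimated as a number 0.9 percentage points higher from compound 3 to compound 4 (within the scatter). Compound 4 is expected to give about 7%, within a range from 0% to 17%.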

Compound 4, percent growth inhibition at one concentration: 0.19%
Compound 4: the middle estimate sits 6.8 percentage points above what was measured; the range from low to high includes it.
By their numbers in this assay, from the lowest: compounds 4, 3, 2 and 1 (each within the scatter of the next).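

Phenethyl is the first group in this set joined to the sulfur through a chain rather than by an aromatic ring, and the steps to it remain within the scatter in this assay: a number 5.9 percentage points lower from compound 3 to compound 4 (within the scatter), a number 6.9 percentage points lower from compound 2 to compound 4 (within the scatter) and a number 9.9 percentage points lower from compound 1 to compound 4 (within the scatter). Exchange at this sulfur has therefore not separated the compounds, even with this change in how the ring is attached. No available measurement explains these numbers. From the compounds shown here alone, whether a longer chain, or a chain ending in an amine or a carboxylic acid, would give a step beyond the scatter remains open.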